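Amino for Chloro on the Fused Ring of Compound 2

A few compounds are considered here, and "the series" means these few. Any claim that something is new, unique, unknown or untested is made for them only; others in the source may bear on it.

Measured so far in a functional assay on IGROV-1 cells (Homo sapiens) for antiproliferative activity, read by sulforhodamine B assay, with a stated time of 48 h; a higher number here means a weaker inhibitor of growth, a lower number a stronger inhibitor of growth:
compound 1, `Nc1nn(C(=O)Nc2ccc(Cc3ccccc3)cc2)c2ccccc12`: 6980 nM
compound 2, `Nc1nn(C(=O)Nc2ccc(Cc3ccccc3)cc2)c2ccc(Cl)cc12`: 13700 nM

Among the measured compounds shown here, only two compounds have numbers in this assay. Compound 1 gives 6980 nM and compound 2 gives 13700 nM. For the measured compounds named here, the step of a 2.0-fold higher number from compound 1 to compound 2 (0.29 log units; within the scatter) lies within the scatter, so the two compounds are not separated; the number of compound 2 is the one nearest the top of the pair, with compound 1 the sole neighbour.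

Compound 3 `Nc1ccc2c(c1)c(N)nn2C(=O)Nc1ccc(Cc2ccccc2)cc1` differs from compound 2 by amino in place of chloro on an aromatic carbon. Going by the values given here, the only measured step, a 2.0-fold higher number from compound 1 to compound 2 (0.29 log units; within the scatter), exchanged hydrogen for chloro and stayed within the scatter; no measured compound carries an amino group in place of the chloro. Nothing measured therefore points to a shift beyond the scatter in this assay. Compound 3 is expected to give about 10000 nM, between 3500 nM and 30000 nM. The expected step of a 1.4-fold lower number from compound 2 to compound 3 (0.14 log units; within the scatter) is thus estimated to stay within the scatter.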

Compound 3, concentration for 50% growth inhibition: 16400 nM
The estimate for compound 3 lay 1.6-fold (0.21 log units) below the measured number; the range from low to high includes it.
By their numbers in this assay, from the lowest: compounds 1, 2 and 3 (each within the scatter of the next, the first and the last beyond it).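

In this assay, exchanging chloro for amino gives a 1.2-fold higher number from compound 2 to compound 3 (0.08 log units; within the scatter) and leaves the two compounds unseparated, even though the amino group brings a hydrogen-bond donor and a hydrogen-bond acceptor that chloro lacks. Among the compounds shown here, measured against hydrogen at the same aromatic carbon, amino gives a 2.3-fold higher number from compound 1 to compound 3 (0.37 log units; beyond the scatter) and so makes compound 3 a weaker inhibitor of growth than compound 1, the first step in this short series to pass beyond the scatter, though only a modest one. No supporting evidence accounts for either step.

On these data alone, it remains open whether other groups at this position, such as methoxy, a carboxylic acid or a longer chain, would fall with chloro and amino or apart from them. The three compounds also leave open whether amino would give the same step on a different carbon of this ring.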